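From Isopropyl to Carboxymethyl on the Amide Side Chain

A few compounds are considered here, and "the series" means these few. Any claim that something is new, unique, unknown or untested is made for them only; others in the source may bear on it.

Compound 1 `CCn1c(C(=O)N[C@@H](C)CO)ccc1C(CC)(CC)c1ccc(OCS(=O)(=O)c2ccccc2)c(C)c1`: 15300 nM
Compound 2 `CCn1c(C(=O)N[C@@H](CO)CCCO)ccc1C(CC)(CC)c1ccc(OCS(=O)(=O)c2ccccc2)c(C)c1`: 16400 nM
Compound 3 `CCn1c(C(=O)N[C@H](C(=O)O)C(C)C)ccc1C(CC)(CC)c1ccc(OCS(=O)(=O)c2ccccc2)c(C)c1`: 16200 nM

These values come from a functional assay on BXPC-3 cells (Homo sapiens) for antiproliferative activity, read by MTT assay, with a stated time of 24 h; on this read-out lower numbers stand for stronger inhibition and higher numbers for weaker inhibition. Compound 3, at 16200 nM, cannot be told apart from the other two compounds, since a 1.1-fold higher number from compound 1 to compound 3 (0.02 log units; within the scatter) and a 1.0-fold lower number from compound 2 to compound 3 (0.01 log units; within the scatter) are both within the scatter.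

Compound 4 `CCn1c(C(=O)N[C@@H](CC(=O)O)C(=O)O)ccc1C(CC)(CC)c1ccc(OCS(=O)(=O)c2ccccc2)c(C)c1` differs from compound 3 in one group: carboxymethyl in place of isopropyl on a saturated chain carbon bound to an amide-type nitrogen and a carbonyl carbon. This is carboxymethyl in place of isopropyl on a saturated chain carbon bound to an amide-type nitrogen and a carbonyl carbon, which turns 1-carboxy-2-methylpropyl into 1,2-dicarboxyethyl.

Among the measured compounds shown here, no measured step makes this exact change, and no measured compound carries 1,2-dicarboxyethyl. The closest evidence is two other changes on the amide-type nitrogen: a 1.1-fold higher number from compound 1 to compound 2 (0.03 log units; within the scatter) and a 1.1-fold higher number from compound 1 to compound 3 (0.02 log units; within the scatter). Both are small, so no step beyond the scatter is expected in this assay, and no direction can be favoured. The estimated step is a 1.0-fold higher number from compound 3 to compound 4 (0.02 log units; within the scatter). For compound 4, the expected value is 17000 nM, within an estimated range of 9000 nM to 32000 nM.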

Compound 4, half-maximal inhibitory concentration: > 50000 nM
Compound 4: only a limit was reported; the forecaster's own chance of this, stated with the estimate: 15%; middle value at least 2.9-fold (0.46 log units) from the limit.
By their numbers in this assay, from the lowest: compounds 1, 3 and 2 (each within the scatter of the next). At a limit, above all of these: compound 4.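

In this assay, the earlier changes on the amide-type nitrogen all stayed within the scatter, so this position seemed to accept quite different groups, yet carboxymethyl in place of isopropyl gives an at least 3.0-fold higher number from compound 3 to compound 4 (0.48 log units; beyond the scatter). The other two compounds point the same way, with an at least 3.0-fold higher number from compound 2 to compound 4 (0.48 log units; beyond the scatter) and an at least 3.2-fold higher number from compound 1 to compound 4 (0.51 log units; beyond the scatter), which makes compound 4, carrying 1,2-dicarboxyethyl, the weakest of the four. For compound 4 only a limit was reported, not a number, so the full size of these steps stays unknown: the limit of > 50000 nM in this assay, at which 1 of the 4 values shown sits.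

From the compounds shown here alone, whether the acid of the carboxymethyl group itself matters remains open, and a methyl ester or a primary amide in its place could help to settle that. Going by these compounds, how an amine, or a longer chain ending in a carboxylic acid, would read in this assay is also open.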